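Azetidinylmethoxy pyridines: ring substituent variation and receptor affinity

The source may hold more compounds than are shown below. What is called first, only, known or untested is meant among the compounds shown, and "the series" means these compounds.

Measured so far:
compound 1, `Cc1cncc(OC[C@@H]2CCN2)c1`, 0.047 nM
compound 2, `CCCc1cncc(OC[C@@H]2CCN2)c1`, 0.039 nM

Compound 2 holds the lowest of the two numbers in an assay on brain for binding affinity to Neuronal acetylcholine receptor; alpha4/beta2 (Rattus norvegicus), read by radioligand binding (on this read-out lower numbers stand for stronger inhibition and higher numbers for weaker inhibition), with compound 1 nearest at a 1.2-fold lower number from compound 1 to compound 2 (0.08 log units; within the scatter). Compound 3, `CCOc1cncc(OC[C@@H]2CCN2)c1`, carries ethoxy in place of propyl on an aromatic carbon, on an aromatic carbon of a six-membered aromatic ring with one nitrogen, two atoms from the ring nitrogen. Among the compounds with values here, the only measured step at this position is the one from compound 1 to compound 2, which stayed within the scatter, so a change no larger than that is expected: a 1.3-fold higher number from compound 2 to compound 3 (0.11 log units; within the scatter). Compound 3 is estimated at 0.05 nM, range 0.015 nM to 0.17 nM.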

Compound 3, inhibition constant: 0.039 nM
Estimate against measurement, compound 3: 1.3-fold (0.11 log units) above, and the stated range covers the measured number.
By their numbers in this assay, from the lowest: compounds 2, 3 and 1 (each within the scatter of the next).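

In this assay, ethoxy in place of propyl on this aromatic carbon gives no separation (no change at the digits printed from compound 2 to compound 3 (within the scatter)), and ethoxy in place of methyl gives none either (a 1.2-fold lower number from compound 1 to compound 3 (0.08 log units; within the scatter)). The position therefore takes an oxygen-linked group with a hydrogen-bond acceptor, as well as the two plain alkyl groups, with all three compounds within the scatter of one another. No evidence at hand accounts for this flat result.

On these data alone, whether an amine, a carboxylic acid or a longer chain at this position would stay within the same range remains open.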